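The source may report more compounds than this note shows. Statements on the series, on what has been measured and on what is new or still open speak of the compounds shown alone.

Three sulfonyl-amidine compounds built on two related cores have been measured, and a fourth awaits measurement. Compound 1 `Cc1cc(S(=O)(=O)/N=C(\N)n2nccc2-c2ccccc2)c(SCc2cccc(Cl)c2)cc1Cl` and compound 2 `Cc1cc(S(=O)(=O)/N=C(\N)n2nccc2-c2ccccc2)c(SCc2cccc(C(F)(F)F)c2)cc1Cl` share one core; compound 3 `Cc1cc(-c2ccccc2)n(/C(N)=N/S(=O)(=O)c2cc(C)c(Cl)cc2SCc2ccccc2C(F)(F)F)n1` is built on the second core, and the difference between the two cores is not broken down here. The unmeasured compound 4 `Cc1cc(-c2ccccc2)n(/C(N)=N/S(=O)(=O)c2cc(C)c(Cl)cc2SCc2ccccc2Cl)n1` shares the core of compound 3.

In a functional assay on HeLa cells (Homo sapiens) for cytotoxicity, read by MTT assay, with a stated time of 72 h (on this read-out lower numbers stand for stronger inhibition and higher numbers for weaker inhibition), compound 1 gives 10000 nM and compound 2 gives 19000 nM. The change from compound 2 to compound 1 is chloro in place of trifluoromethyl on an aromatic carbon and made a step of a 1.9-fold lower number from compound 2 to compound 1 (0.28 log units; within the scatter). Compound 3 gives 215000 nM in this assay, which is the highest of the three numbers, beyond the scatter from both compound 2 and compound 1.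

Among the measured compounds shown here, compound 4 is reached from compound 3 by chloro in place of trifluoromethyl on an aromatic carbon, the same kind of change as the one from compound 2 to compound 1, though not the same: here the chloro sits ortho to a large group, whereas in compound 1 it sits meta to a large group. For the measured compounds named here, because the earlier step of a 1.9-fold lower number from compound 2 to compound 1 (0.28 log units; within the scatter) stayed within the scatter, a small step of a 1.4-fold lower number from compound 3 to compound 4 (0.16 log units; within the scatter) is expected in this assay, and that expectation rests on only one measured pair on a different core. Compound 4 is therefore estimated at 150000 nM, expected to fall between 60000 nM and 400000 nM.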

Compound 4, half-maximal inhibitory concentration: 270000 nM
For compound 4 the middle estimate is 1.8-fold (0.26 log units) below the measured one; the range from low to high includes it.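

In this assay, chloro in place of trifluoromethyl on the aromatic carbon gave a 1.3-fold higher number from compound 3 to compound 4 (0.10 log units; within the scatter), so on this core too the change made only a small step. Set beside the earlier pair, the two steps do not differ beyond the scatter, and in this narrow sense the change carried over from one core to the other: the same change on two cores in this assay, a 1.9-fold lower number (0.28 log units; within the scatter) from compound 2 to compound 1 and a 1.3-fold higher number (0.10 log units; within the scatter) from compound 3 to compound 4, 2.4-fold (0.38 log units) apart, within the scatter of two such steps This does not show that the step is the same on every core of the series, since it rests on only two pairs, and those pairs differ both in the core and in where the group sits on the ring, ortho to a large group in compound 4 but not in compound 1, so the data cannot separate these two influences or say how either one acts.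

The compounds shown leave open whether the step would stay as small with the chloro and trifluoromethyl groups in one and the same place on both cores. They also leave open how that ring would respond to a different kind of group there, such as a methoxy group, a nitrile, an amine or a carboxylic acid, or how a longer chain in place of the benzyl link would read out in this assay.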